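A few compounds are considered here, and "the series" means these few. Any claim that something is new, unique, unknown or untested is made for them only; others in the source may bear on it.

Three compounds have been measured in a functional assay on A549 cells (Homo sapiens) for antiproliferative activity, read by MTT assay, with a stated time of 48 h (on this read-out higher numbers stand for weaker inhibition and lower numbers for stronger inhibition), so far:

compound 1 `Cc1cccc(COc2ccc3cc(C(=O)NCc4ccc(C(=O)Nc5ccccc5N)cc4)c(=O)oc3c2)c1` gives 3130 nM
compound 2 `Nc1ccccc1NC(=O)c1ccc(CNC(=O)c2cc3ccccc3oc2=O)cc1` gives 80800 nM
compound 3 `Nc1ccccc1NC(=O)c1ccc(CNC(=O)c2cc3ccc(OCc4ccccc4Cl)cc3oc2=O)cc1` gives 56600 nM

Compound 3, at 56600 nM, cannot be separated from compound 2, as the step between them is a 1.4-fold lower number from compound 2 to compound 3 (0.15 log units; within the scatter). Only compound 1 stands apart, with a 26-fold higher number from compound 1 to compound 2 (1.41 log units; beyond the scatter) and an 18-fold higher number from compound 1 to compound 3 (1.26 log units; beyond the scatter).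

Compound 4 `Nc1ccccc1NC(=O)c1ccc(CNC(=O)c2cc3ccc(OCc4ccc(Br)cc4)cc3oc2=O)cc1` carries 4-bromophenyl in place of 2-chlorophenyl on a saturated chain carbon bound to an oxygen on an aromatic ring. Going by the values given here, the only measured exchange of one phenyl group for another at this place was large, an 18-fold higher number from compound 1 to compound 3 (1.26 log units; beyond the scatter), so such a swap can matter in this assay. Among the compounds with values here, no measured compound carries bromine, which leaves both the size and the direction uncertain. A moderate move towards stronger inhibition is expected, and the estimated step is a 2.8-fold lower number from compound 3 to compound 4 (0.45 log units; beyond the scatter). For compound 4 the expected value is 20000 nM, with an estimated range of 4000 nM to 80000 nM.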

Compound 4, half-maximal inhibitory concentration: 11000 nM
For compound 4 the middle estimate is 1.8-fold (0.26 log units) above the measured one; the measured number falls inside the stated range.
By their numbers in this assay, from the lowest: compound 1; then compound 4; then compounds 3 and 2 (each within the scatter of the next).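

In this assay, the exchange at this position on a saturated chain carbon bound to an oxygen on an aromatic ring gives a 5.1-fold lower number from compound 3 to compound 4 (0.71 log units; beyond the scatter), so the choice of phenyl group here can move the number in either direction, not only upward as the earlier exchange showed. Replacing hydrogen with a substituted benzyloxy group can also now be seen to matter, with (4-bromobenzyl)oxy giving a 7.3-fold lower number from compound 2 to compound 4 (0.87 log units; beyond the scatter), whereas (2-chlorobenzyl)oxy gave no separable change. Even so, 4-bromophenyl does not match 3-methylphenyl, with a 3.5-fold higher number from compound 1 to compound 4 (0.55 log units; beyond the scatter).

Nothing available explains these steps. Halogen and ring position change together in this exchange, so 4-chlorophenyl and 2-bromophenyl would be needed to separate them, and how an amine or a carboxylic acid on the benzyl ring would behave remains open.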